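This account rests on a few compounds, and the source may have more. Where it says the series, first, only, none or still open, it means among the compounds named here.

Compound 1 `NC(=O)N1CCN(C(=S)SCc2cn(Cc3ccccc3F)nn2)CC1` gives 43100 nM in a functional assay on EC9706 cells (Homo sapiens) for cytotoxicity, read by MTT assay, with a stated time of 72 h; on this read-out lower numbers stand for stronger inhibition and higher numbers for weaker inhibition. Compound 2 `NC(=O)N1CCN(C(=S)SCc2cn(Cc3ccc(Cl)cc3)nn2)CC1` reaches only the limit of the assay there, > 128000 nM, and so stands at the weak end of the numbers shown. Among the measured compounds shown here, the single measured step, an at least 2.9-fold higher number from compound 1 to compound 2 (0.47 log units; beyond the scatter), runs into that limit (the limit of > 128000 nM in this assay, at which 1 of the 2 values shown sits). Compound 3 `Cc1ccc(Cn2cc(CSC(=S)N3CCN(C(N)=O)CC3)nn2)cc1` differs from compound 2 by methyl in place of chloro on an aromatic carbon. For the measured compounds named here, with only that one step to lean on, no step beyond the scatter is expected, and the step this expectation means is an at least 1.1-fold lower number from compound 2 to compound 3 (0.06 log units; that floor lies within the scatter). Compound 3 is therefore expected to give about 110000 nM, between 35000 nM and 350000 nM, quite possibly again only a limit.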

Compound 3, half-maximal inhibitory concentration: > 128000 nM
Compound 3 gave a limit, no number (the forecaster's own chance of this, stated with the estimate: 55%); at least 1.1-fold (0.06 log units) between middle value and limit.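

Putting methyl in place of chloro on this aromatic carbon, para to a large group, does not bring a readable value back in this assay, and the step between compound 2 and compound 3 cannot be read. The readable step, an at least 2.9-fold higher number from compound 1 to compound 3 (0.47 log units; beyond the scatter), shows that 4-methylphenyl, like 4-chlorophenyl, gives weaker inhibition than 2-fluorophenyl. Any finer comparison of chloro and methyl stops there: the limit of > 128000 nM in this assay, at which 2 of the 3 values shown sit.

Going by these compounds, it remains open whether an amine or a carboxylic acid at this place would give a readable value. On these data alone, it also remains open whether fluoro, para to a large group, would match the value of compound 1 at 43100 nM.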